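Adding a Second Methoxy Group to an Amide Analogue

The compounds below may be only part of what the source reports. "The series", "measured", "known", "first", "only" and "open" are said of these compounds alone.

Compound 1 `COc1ccc(C(=O)/C=C/c2ccccc2-c2ccc(F)nc2)cc1` and compound 2 `COc1ccc(C(=O)/C=C/c2ccccc2-c2ccc(F)nc2)cc1OC` share one core, and compound 2 differs from compound 1 only by methoxy in place of hydrogen on an aromatic carbon. In a functional assay on A549 cells (Homo sapiens) for antiproliferative activity, read by sulforhodamine B assay, with a stated time of 48 h (on this read-out lower numbers stand for stronger inhibition and higher numbers for weaker inhibition), compound 1 gives only a limit, > 50000 nM. In this assay compound 2 gives 17000 nM, so the change made an at least 2.9-fold lower number from compound 1 to compound 2 (0.46 log units; beyond the scatter). Compound 3 `COc1ccc(CNC(=O)c2ccccc2-c2ccc(F)cc2)cc1` is built on another core; the difference between the two cores is not broken down here. In this assay compound 3 also gives only a limit, > 50000 nM. Compound 4 `COc1ccc(CNC(=O)c2ccccc2-c2ccc(F)cc2)cc1OC` is not yet measured and differs from compound 3 by the same change, (methoxy in place of hydrogen on an aromatic carbon). The expectation for compound 4 rests on compound 2, where an at least 2.9-fold lower number from compound 1 to compound 2 (0.46 log units; beyond the scatter) was found, while both unsubstituted compounds sit at the limit of > 50000 nM in this assay, at which 2 of the 3 values shown sit. Compound 4 is therefore expected to give about 30000 nM. The expected step is an at least 1.6-fold lower number from compound 3 to compound 4 (0.22 log units; that floor lies within the scatter). For compound 4 the estimated range runs from 10000 nM to 60000 nM.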

Compound 4, half-maximal inhibitory concentration: > 50000 nM
Compound 4: a limit, no number (the forecaster's own chance of this, stated with the estimate: 55%); middle value at least 1.6-fold (0.22 log units) away from the limit.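

In this assay, compound 3 and compound 4 both give only a limit, so no step can be read between them: the limit of > 50000 nM in this assay, at which 3 of the 4 values shown sit.

As far as these compounds go, whether methoxy in place of hydrogen changes the activity on the core of compound 3 stays open.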